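Amide nitrogen substituent swap: pyrimidinyl to thiazolyl

The source may hold more compounds than are shown below. What is called first, only, known or untested is meant among the compounds shown, and "the series" means these compounds.

Compound 2 `COc1ccc2nc(C)cc(OCC(=O)Nc3ccncn3)c2c1` gives the lowest of the two numbers in a physicochemical assay for solubility, in phosphate buffer, measured as kinetic solubility, with a stated time of 1 h, at pH 7.4 (a higher number here means a more soluble compound, a lower number a less soluble compound), where compound 2 shows 27500 nM. Its nearest neighbour, compound 1 `COc1ccc2nc(C)cc(OCC(=O)Nc3cccc(C)c3)c2c1`, gives 193000 nM in this assay; the step was a 7.0-fold lower number from compound 1 to compound 2 (0.85 log units; beyond the scatter). Compound 3 `COc1ccc2nc(C)cc(OCC(=O)Nc3nccs3)c2c1` differs from compound 2 by 1,3-thiazol-2-yl in place of pyrimidin-4-yl on an amide-type nitrogen. For the measured compounds named here, no measured step covers this pairing of two heteroaryl groups; the one recorded step bears on it only loosely, so a step within or near the scatter is expected, leaning lower. For compound 3 the expected value in this assay is 18000 nM (range 5000 nM to 60000 nM), an expected step of a 1.5-fold lower number from compound 2 to compound 3 (0.18 log units; within the scatter).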

Compound 3, solubility: 54000 nM
Beside the measured number, compound 3's estimate is 3.0-fold (0.48 log units) below it; low and high end bracket the measured number.
By their numbers in this assay, from the lowest: compounds 2 and 3 (each within the scatter of the next); then compound 1.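

In this assay, 1,3-thiazol-2-yl in place of pyrimidin-4-yl on the amide-type nitrogen gives a 2.0-fold higher number from compound 2 to compound 3 (0.29 log units; within the scatter), so this exchange of one heteroaryl group for the other does not separate the two compounds. Replacing 3-methylphenyl with 1,3-thiazol-2-yl gives a 3.6-fold lower number from compound 1 to compound 3 (0.55 log units; beyond the scatter), and with the earlier pyrimidin-4-yl step, both heteroaryl replacements of 3-methylphenyl now give lower numbers beyond the scatter. No evidence is available that bears on this result.

Open: how a pyridin-3-yl ring on this nitrogen compares with these groups, and what a piperidine-bearing chain or a carboxylic acid there would give.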